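The source may hold more compounds than are shown below. What is called first, only, known or untested is meant among the compounds shown, and "the series" means these compounds.

Compound 3 `Clc1ccc(-c2noc(-c3cc4ccccc4[nH]3)n2)cc1` stands at the edge of what a functional assay on Jurkat cells (Homo sapiens) for antiproliferative activity, read by WST assay, with a stated time of 72 h (on this read-out higher numbers stand for weaker inhibition and lower numbers for stronger inhibition), can report: in this assay compound 3 gives > 50000 nM, which is a limit of the assay and not a number. Compound 1 `Cc1noc(-c2cc3ccccc3[nH]2)n1` likewise reaches only a limit, giving > 50000 nM in this assay. Compound 2 `Fc1ccc2[nH]c(-c3nc(-c4ccccc4)no3)cc2c1` gives 33800 nM in this assay. Within the data shown here, the single step that changes one place, a step that the two limits leave unreadable from compound 1 to compound 3, cannot be read in size since both of its ends sit at the limit of > 50000 nM in this assay, at which 2 of the 3 values shown sit. Compound 4 `Fc1ccc2[nH]c(-c3nc(-c4ccc(Cl)cc4)no3)cc2c1` differs from compound 3 by fluoro in place of hydrogen on an aromatic carbon. Among the measured compounds shown here, no measured step covers this change, so no size or direction beyond the scatter can be expected from it. Compound 4 is therefore estimated to give 45000 nM in this assay, within 15000 nM to 150000 nM, an expected step of an at least 1.1-fold lower number from compound 3 to compound 4 (0.04 log units; that floor lies within the scatter).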

Compound 4, half-maximal inhibitory concentration: > 50000 nM
Compound 4: no number, only a limit (the forecaster's own chance of this, stated with the estimate: 60%); at least 1.1-fold (0.04 log units) between middle value and limit.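

In this assay compound 4 gives > 50000 nM, which is a limit of the assay and not a number. The steps from compound 1 to compound 3 and from compound 3 to compound 4 cannot be read, because both ends of each sit at the same limit: the limit of > 50000 nM in this assay, at which 3 of the 4 values shown sit. Chloro in place of hydrogen gives an at least 1.4-fold higher number from compound 2 to compound 4 (0.17 log units; that floor lies within the scatter), a floor only, so this change brought no stronger inhibition here. As far as these compounds go, the true size of the fluoro step stays open. So does whether an amine or a carboxylic acid in place of that fluoro would give a readable value.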